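From hydroxy to iodo on the aromatic ring

The source may report more compounds than this note shows. Statements on the series, on what has been measured and on what is new or still open speak of the compounds shown alone.

In a functional assay on HT-29 cells (Homo sapiens) for antiproliferative activity, with a stated time of 48 h (on this read-out higher numbers stand for an effect only at larger amounts of compound and lower numbers for an effect already at smaller amounts), compound 1 `O=C(CCCCCCC(=O)Nc1ccc(O)cc1)NO` gives 15000 nM. This sits level with compound 3 `O=C(CCCCCCC(=O)Nc1ccccc1Br)NO` at 17000 nM, within the scatter, while compound 2 `O=C(CCCCCCC(=O)Nc1cccc(C(F)(F)F)c1)NO` gives a lower number, 6400 nM, beyond the scatter. Compound 4 `O=C(CCCCCCC(=O)Nc1ccc(I)cc1)NO` has not been measured. It keeps the core of compound 1 with one change: iodo in place of hydroxy on an aromatic carbon. Going by the values given here, no measured pair isolates a swap like this, so the expectation is loose. The expected step is small and towards a lower number, probably within the scatter, a 1.7-fold lower number from compound 1 to compound 4 (0.22 log units; within the scatter). For compound 4 the estimated value is 9000 nM, within an expected range from 3500 nM to 20000 nM.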

Compound 4, half-maximal effective concentration: 950 nM
For compound 4 the middle estimate is 9.5-fold (0.98 log units) above the measured one, outside the stated range (below it).
By their numbers in this assay, from the lowest: compound 4; then compound 2; then compounds 1 and 3 (each within the scatter of the next).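

Replacing hydroxy with iodo on this aromatic carbon, para to a large group, gives a 16-fold lower number from compound 1 to compound 4 (1.20 log units; beyond the scatter) in this assay. Going by these compounds alone, this shows that exchanging one heavy atom at this position can change the read-out strongly, which the earlier compounds could not show because none of them differed in only one place. Nothing available explains why this step is so large. As far as these compounds go, it remains open whether the drop is specific to iodo or would also occur with chloro, methoxy or an amine on the same carbon.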